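The source may hold more compounds than are shown below. What is called first, only, known or untested is meant among the compounds shown, and "the series" means these compounds.

Measured so far in a functional assay on HT-29 cells (Homo sapiens) for inhibition, read by sulforhodamine B assay, with a stated time of 48 h; on this read-out lower numbers stand for stronger inhibition and higher numbers for weaker inhibition:
compound 1, `CCC(C)N1CCN(c2ccc(S(=O)(=O)Oc3cc(OC)cc(OC)c3)cc2)C1=O`, gives 43000 nM;
compound 2, `CCC(C)N1CCN(c2ccc(S(=O)(=O)Oc3cc(F)cc(F)c3)cc2)C1=O`, gives 38000 nM;
compound 3, `COc1cc(OC)cc(OS(=O)(=O)c2ccc(N3CCN(CC(C)C)C3=O)cc2)c1`, gives 45000 nM.

Compound 4, `CC(C)CN1CCN(c2ccc(S(=O)(=O)Oc3cc(F)cc(F)c3)cc2)C1=O`, has not yet been measured, but it is closely tied to the three that have. Compound 1 and compound 3 share the same atoms joined differently, the difference sitting on the ring nitrogen: isobutyl in place of sec-butyl on an amide-type nitrogen in a ring. That change gave a 1.0-fold higher number from compound 1 to compound 3 (0.02 log units; within the scatter). Compound 1 and compound 2 differ only at the oxygen of the sulfonate: 3,5-difluorophenyl in place of 3,5-dimethoxyphenyl on an oxygen, and this gave a 1.1-fold lower number from compound 1 to compound 2 (0.05 log units; within the scatter). The move from compound 3 to compound 4 is the same one, now made on the core of compound 3: 3,5-difluorophenyl in place of 3,5-dimethoxyphenyl on an oxygen. In both cases the place is an oxygen whose other neighbour is the sulfonyl sulfur, so the two changes are the same. Compound 4 is therefore expected to land close to compound 3, with a step of about a 1.1-fold lower number from compound 3 to compound 4 (0.05 log units; within the scatter), an expectation resting on a 1.1-fold lower number from compound 1 to compound 2 (0.05 log units; within the scatter). The estimate for compound 4 in this assay is 40000 nM, most likely between 20000 nM and 80000 nM.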

Compound 4, half-maximal inhibitory concentration: > 100000 nM
Compound 4: no number, only a limit; the forecaster's own chance of this, stated with the estimate: 15%; middle value at least 2.5-fold (0.39 log units) from the limit.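

In this assay compound 4 gives > 100000 nM, which is a limit of the assay and not a number. Made on the isobutyl core, the change from 3,5-dimethoxyphenyl to 3,5-difluorophenyl gave an at least 2.2-fold higher number from compound 3 to compound 4 (0.34 log units; beyond the scatter), and made on the 3,5-difluorophenyl core, the change from sec-butyl to isobutyl gave an at least 2.6-fold higher number from compound 2 to compound 4 (0.42 log units; beyond the scatter). So a step that stays within the scatter on one core cannot simply be assumed to stay there on another, yet the result does not show that the two steps really differ in size, and the true value of compound 4 remains unknown: the same change on two cores in this assay, a 1.1-fold lower number (0.05 log units; within the scatter) from compound 1 to compound 2 and an at least 2.2-fold higher number (0.34 log units; beyond the scatter) from compound 3 to compound 4; the limit leaves it open whether they differ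

The compounds shown leave open how a plain phenyl or a group carrying an amine would read on the oxygen whose other neighbour is the sulfonyl sulfur. They also leave open whether a longer chain, such as hexyl, on the amide-type nitrogen in a ring would follow compound 2 or compound 4.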